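The source may hold more compounds than are shown below. What is called first, only, known or untested is meant among the compounds shown, and "the series" means these compounds.

Measured so far:
- Compound 1, `CC(=O)N1CCN(c2cncc(N3C(=O)c4ccc(Cl)cc4C3(C)C)c2)CC1`: 9 nM
- Compound 2, `CCC(=O)N[C@@H]1CCCc2c1cncc2N1C(=O)c2ccc(Cl)cc2[C@@H]1CC`: 12 nM
- Compound 3, `CC(=O)N[C@@H]1CCCc2c1cncc2N1C(=O)c2ccc(Cl)cc2[C@H]1C1CC1`: 100 nM

In an assay on cells for inhibition of cytochrome P450 11B2, mitochondrial (Homo sapiens), read by HTRF (on this read-out lower numbers stand for stronger inhibition and higher numbers for weaker inhibition), compound 2 gives 12 nM and stands second highest of the three numbers. Its nearest neighbour is compound 1, which in this assay gives 9 nM, a gap that lies within the scatter, so the two cannot be told apart. Going by the values given here, its furthest is compound 3, which gives 100 nM, a gap beyond the scatter; the two values show compound 3 weaker, though no single-point step links them.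

Compound 4, `CCC(=O)N[C@@H]1CCCc2c1cncc2N1Cc2cc(Cl)ccc2C1=O`, has not been measured. It differs from compound 2 by hydrogen in place of ethyl on a saturated ring carbon. Among the compounds with values here, no step between measured compounds shows what removing a group at this carbon does; compound 3 carries a different group there and is weaker, which gives no guidance on a bare carbon. A small loss, possibly within the scatter, is expected: the step from a 2.5-fold higher number from compound 2 to compound 4 (0.40 log units; beyond the scatter) is estimated. Compound 4 is expected at 30 nM, within 8 nM to 120 nM.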

Compound 4, half-maximal inhibitory concentration: 28 nM
Estimate against measurement, compound 4: 1.1-fold (0.03 log units) above, and the stated range covers the measured number.
By their numbers in this assay, from the lowest: compounds 1 and 2 (each within the scatter of the next); then compound 4; then compound 3.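

In this assay, going by these compounds alone, hydrogen in place of ethyl on the saturated ring carbon next to the ring nitrogen gives a 2.3-fold higher number from compound 2 to compound 4 (0.37 log units; beyond the scatter) as a modest change beyond the scatter, the first direct reading at this position. The ethyl therefore contributes measurably in this pair, yet compound 4 at 28 nM shows that inhibition survives with no group on this carbon. No measurement shown here explains the size of this step.

With only ethyl and hydrogen compared directly at this carbon, the compounds leave open whether methyl, a longer chain such as propyl, or an amine would give a lower or higher number than ethyl. They also leave open whether the same change would have a similar size on a core carrying a different amide.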